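The compounds below may be only part of what the source reports. "The series", "measured", "known", "first", "only" and "open" are said of these compounds alone.

Measured in a functional assay on the whole organism (strain Wistar) with Rattus norvegicus as the target, with a stated time of 5 min; on this read-out higher numbers stand for an effect only at larger amounts of compound and lower numbers for an effect already at smaller amounts:

compound 1 `CCC1(CCCCN2CCN(c3cccc(Cl)c3)CC2)C(=O)Nc2cc(F)ccc21`: > 20 mg/kg, a limit of the assay rather than a number
compound 2 `CCC1(CCCCN2CCN(c3cccc(Cl)c3)CC2)C(=O)Nc2cc(F)c(Cl)cc21`: 20 mg/kg
compound 3 `CCC1(CCCCN2CCN(c3ccccc3)CC2)C(=O)Nc2ccccc21`: 10 mg/kg

Compound 1 and compound 2 share one core and differ by chloro in place of hydrogen on an aromatic carbon. The step of a number no higher from compound 1 to compound 2 (the limit leaves the size open) has no readable size, because of the limit of > 20 mg/kg in this assay, at which 1 of the 3 values shown sits. Compound 3 stands on a different core; the difference between the core of compound 1 and the core of compound 3 is not broken down here. Compound 2 and compound 3 lie within the usual scatter of each other in this assay, so no order between them is claimed.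

Compound 4 `CCC1(CCCCN2CCN(c3cccc(Cl)c3)CC2)C(=O)Nc2ccccc21` is not yet measured. It differs from compound 3 by chloro in place of hydrogen on an aromatic carbon. This is the same kind of change as that from compound 1 to compound 2, but not the same: in compound 2 the chloro enters on a ring that is part of a fused or bridged system of two rings, ortho to a fluoro group, meta to a fused ring and para to a fused ring, whereas in compound 4 it enters on a six-membered aromatic ring of carbon only, meta to a large group.

Among the measured compounds shown here, for compound 4 the only anchor is compound 3 at 10 mg/kg, since the measured step from compound 1 to compound 2 gives no size. The step of no change at the digits printed from compound 3 to compound 4 (within the scatter) is expected to be small. Compound 4 is estimated at 10 mg/kg, with a range from 5 mg/kg to 20 mg/kg.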

Compound 4, minimum effective dose: > 20 mg/kg
Compound 4 was reported as a limit; the forecaster's own chance of this, stated with the estimate: 20%; middle value at least 2.0-fold (0.30 log units) from the limit.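

In this assay compound 4 gives > 20 mg/kg, which is a limit of the assay and not a number. On the six-membered aromatic ring of carbon only, the change from phenyl to 3-chlorophenyl gives an at least 2.0-fold higher number from compound 3 to compound 4 (0.30 log units; that floor lies within the scatter), so this case shows no gain from chloro but does not establish a shift beyond the usual scatter, and set beside the earlier case on the fused system it reads: the same change on two cores in this assay, a number no higher (the limit leaves the size open) from compound 1 to compound 2 and an at least 2.0-fold higher number (0.30 log units; that floor lies within the scatter) from compound 3 to compound 4; the limit leaves it open whether they differ. The series therefore shows neither that the change carries over from one core to another nor that it fails to, since the two cases also differ in where the chloro enters, and the remaining steps among these compounds cannot be read: the limit of > 20 mg/kg in this assay, at which 2 of the 4 values shown sit.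

Going by these compounds, it stays open whether a methoxy or trifluoromethyl group in place of chloro on the same ring would give a number instead of a limit, and what chloro does at other places on that ring. Also open, on these data alone, is whether fluoro on the core of compound 3, with the plain phenyl kept, or a longer chain in place of the present one, would bring a readable value.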